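A few compounds are considered here, and "the series" means these few. Any claim that something is new, unique, unknown or untested is made for them only; others in the source may bear on it.

Compound 1 `COC(=O)c1ccc(NCc2cncn2Cc2ccc([N+](=O)[O-])cc2)cc1-c1ccccc1`: > 10000 nM
Compound 2 `COC(=O)c1ccc(NCc2cncn2Cc2ccccc2OC)cc1-c1ccccc1`: "not determined" (no result reported)

In a toxicity assay on NIH3T3 cells (Mus musculus) for cytotoxicity, read by resazurin assay (on this read-out lower numbers stand for an effect already at smaller amounts and higher numbers for an effect only at larger amounts of compound), compound 1 gives > 10000 nM, which is a limit of the assay. Compound 2 has no single number, its result being "not determined" (no result reported). The only reference point is the limit of > 10000 nM in this assay, at which 1 of the 2 values shown sits. Compound 3 `COC(=O)c1ccc(NCc2cncn2Cc2ccccc2C#N)cc1-c1ccccc1` is still unmeasured. The change cyano in place of methoxy on an aromatic carbon puts cyano in place of methoxy on an aromatic carbon, ortho to a large group. No step beyond the scatter is expected in this assay. That expectation rests on compound 1, whose > 10000 nM is a limit. Compound 3 is expected near 10000 nM, within an estimated range of 4000 nM to 25000 nM.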

Compound 3, half-maximal effective concentration: 25000 nM
For compound 3 the middle estimate is 2.5-fold (0.40 log units) below the measured one; measured number inside the range.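

No step can be read from compound 1 to compound 3, nor from compound 2 to compound 3. The compounds shown leave open how 2-cyanophenyl compares with 4-nitrophenyl or with 2-methoxyphenyl in this assay.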